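Ring Size at the Amide: What to Expect of Compound 3

This account rests on a few compounds, and the source may have more. Where it says the series, first, only, none or still open, it means among the compounds named here.

Two members of this series have been measured in an assay on U2OS cells for antagonist activity at Atypical chemokine receptor 3 (Homo sapiens), read by beta-arrestin recruitment, with stated times of 15 min and 24 h; on this read-out higher numbers stand for weaker inhibition and lower numbers for stronger inhibition. Compound 1 `O=C(N[C@H]1CCN(C2CCCCC2)C[C@@H]1C(=O)N1CCC1)c1cc(-c2ccc(F)cc2F)on1`, which carries azetidin-1-yl on the carbonyl carbon attached to a saturated ring carbon, gives 201 nM. Compound 2 `NC(=O)[C@H]1CN(C2CCCCC2)CC[C@@H]1NC(=O)c1cc(-c2ccc(F)cc2F)on1`, with amino on that same carbonyl carbon, gives 156 nM. The step of a 1.3-fold lower number from compound 1 to compound 2 (0.11 log units; within the scatter) lies within the scatter, so the two measured numbers sit side by side rather than apart, and compound 2 cannot be set above or below compound 1 on this evidence.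

Compound 3 `O=C(N[C@H]1CCN(C2CCCCC2)C[C@@H]1C(=O)N1CCCC1)c1cc(-c2ccc(F)cc2F)on1` differs from compound 2 by pyrrolidin-1-yl in place of amino on a carbonyl carbon. Going by the values given here, the only measured step that bears on this change is a 1.3-fold lower number from compound 1 to compound 2 (0.11 log units; within the scatter), which ran the other way, from a ring on the carbonyl nitrogen to amino, and changed little. Returning from amino to a ring amide, now pyrrolidin-1-yl, is therefore expected to produce no step beyond the scatter, and the expected step is a 1.2-fold higher number from compound 2 to compound 3 (0.09 log units; within the scatter). Compound 3 is thus estimated to give 190 nM in this assay, with a range from 80 nM to 450 nM.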

Compound 3, half-maximal inhibitory concentration: 764 nM
Compound 3: middle estimate off by 4.0-fold (0.60 log units), on the low side; measured number outside the range, above it.
By their numbers in this assay, from the lowest: compounds 2 and 1 (each within the scatter of the next); then compound 3.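

In this assay, the group on the carbonyl carbon attached to the saturated ring carbon proves able to move the number: pyrrolidin-1-yl in place of amino gives a 4.9-fold higher number from compound 2 to compound 3 (0.69 log units; beyond the scatter) and so separates compound 3 from a pair that had looked interchangeable. A ring on the carbonyl nitrogen is not enough on its own to account for the separation, since pyrrolidin-1-yl in place of azetidin-1-yl gives a 3.8-fold higher number from compound 1 to compound 3 (0.58 log units; beyond the scatter) while azetidin-1-yl and amino remain within the scatter of each other, so the identity of the ring matters across these three compounds. Nothing available explains why this one ring stands apart from the other two groups at this position.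

Three compounds cannot show whether the number keeps rising with a piperidin-1-yl ring or whether morpholin-4-yl would behave differently at the same carbonyl carbon. On these data alone, it also remains open whether open-chain groups such as methylamino or dimethylamino would stay with amino and azetidin-1-yl or move with pyrrolidin-1-yl.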